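Methoxy for Amino on the Benzamide of Compound 2

A few compounds are considered here, and "the series" means these few. Any claim that something is new, unique, unknown or untested is made for them only; others in the source may bear on it.

In a functional assay on MCF7 cells (Homo sapiens) for antiproliferative activity, read by MTT assay, with a stated time of 48 h (a lower number here means a stronger inhibitor, a higher number a weaker inhibitor), compound 2 `CN(C)CCNc1cc2c(cn1)cc(NC(=O)c1ccc(N)cc1)c(=O)n2C` gives 55800 nM, the highest of the three numbers shown. Within the data shown here, compound 1 `CCCNc1cc2c(cn1)cc(NC(=O)c1cccc(-c3ccccc3)c1)c(=O)n2C` gives 6000 nM and compound 3 `CN(C)CCNc1cc2c(cn1)cc(NC(=O)c1cccc(-c3ccccc3)c1)c(=O)n2C` gives 1930 nM; the one step between measured compounds, a 3.1-fold lower number from compound 1 to compound 3 (0.49 log units; beyond the scatter), concerns the chain and not the benzamide ring. Compound 4 `COc1ccc(C(=O)Nc2cc3cnc(NCCN(C)C)cc3n(C)c2=O)cc1` differs from compound 2 by methoxy in place of amino on an aromatic carbon, on an aromatic carbon para to a large group. Among the measured compounds shown here, no measured pair alters this ring substituent, so no step bears directly on the change; the gap between compound 2 and compound 3 shows only that the benzamide substituent can shift the number widely. For compound 4 a modest step toward a lower number is expected, a 2.2-fold lower number from compound 2 to compound 4 (0.35 log units; beyond the scatter), with broad uncertainty. Compound 4 is therefore estimated at 25000 nM, between 7000 nM and 90000 nM.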

Compound 4, half-maximal inhibitory concentration: 37300 nM
The estimate for compound 4 lay 1.5-fold (0.17 log units) below the measured number; the measured number falls inside the stated range.
By their numbers in this assay, from the lowest: compound 3; then compound 1; then compounds 4 and 2 (each within the scatter of the next).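

Among these compounds, this is the first measured pair to alter this ring substituent, and it gives a 1.5-fold lower number from compound 2 to compound 4 (0.17 log units; within the scatter) in this assay. On an aromatic carbon para to a large group, amino and methoxy therefore cannot be told apart in this assay, although they differ in hydrogen-bond donors. No evidence is available that bears on why this exchange leaves the number within the scatter. As far as these compounds go, whether a carboxylic acid or a longer alkoxy chain at this position would shift the number beyond the scatter remains open.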